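A few compounds are considered here, and "the series" means these few. Any claim that something is new, unique, unknown or untested is made for them only; others in the source may bear on it.

Measured so far, in an assay on isolated protein for inhibition of Amine oxidase [flavin-containing] B (Homo sapiens), read by fluorescence and Amplex Red, with a stated time of 15 min, tested at 50 uM; on this read-out higher numbers stand for more inhibition at the one concentration tested (going by the name of the read-out) and lower numbers for less inhibition:
- compound 1 `C#CCN(CC)Cc1cn(-c2cc(NC(=S)NCC)ncn2)cn1` gives 35.1%
- compound 2 `C#CCN(CCC)Cc1cn(-c2cc(NC(=S)NCC)ncn2)cn1` gives 24.3%
- compound 3 `C#CCN(CC#N)Cc1cn(-c2cc(NC(=S)NCC)ncn2)cn1` gives 15.4%

Compound 3 stands lowest of the three. Its nearest neighbour is compound 2, reached by a number 8.9 percentage points lower from compound 2 to compound 3 (within the scatter), a step within the scatter; the furthest is compound 1, reached by a number 19.7 percentage points lower from compound 1 to compound 3 (beyond the scatter), a step beyond the scatter. Compound 4 `C#CCN(CC#C)Cc1cn(-c2cc(NC(=S)NCC)ncn2)cn1` differs from compound 3 in one place: ethynyl in place of cyano on a saturated chain carbon bound to an amine nitrogen. The two steps that bear on this change are those that put cyano onto the same carbon, a number 19.7 percentage points lower from compound 1 to compound 3 (beyond the scatter) and a number 8.9 percentage points lower from compound 2 to compound 3 (within the scatter), both losses. Taking cyano away again for ethynyl is therefore expected to give back part of that loss, a modest rise that may still lie within the scatter: a number 7.6 percentage points higher from compound 3 to compound 4 (within the scatter). Compound 4 is estimated at 23%, between 10% and 36%.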

Compound 4, a percentage reported as inhibition, at one concentration (the size of the read-out at that concentration, not a potency): 42.1%
Estimate against measurement, compound 4: 19.1 percentage points below, outside the stated range (above it).
By their numbers in this assay, from the lowest: compounds 3 and 2 (each within the scatter of the next); then compounds 1 and 4 (each within the scatter of the next).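

In this assay, the loss on this saturated chain carbon does not follow from having a triple bond, since ethynyl and cyano each carry one, yet the swap gives a clear gain (a number 26.7 percentage points higher from compound 3 to compound 4 (beyond the scatter)). Ethynyl also stands clear of ethyl (a number 17.8 percentage points higher from compound 2 to compound 4 (beyond the scatter)) but not of methyl (a number 7 percentage points higher from compound 1 to compound 4 (within the scatter)), so the identity of the group matters here, not only the length of the chain. Nothing measured here explains these differences. Still open, on these data alone, is how a hydroxyl, an amine or a phenyl group on this carbon would read, and whether any of them would stand clear of both compound 1 and compound 4.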